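Triazole for methylpyrazole in the aryl-imidazoline series

The compounds below may be only part of what the source reports. "The series", "measured", "known", "first", "only" and "open" are said of these compounds alone.

Compound 2 `Cn1nccc1-c1ccccc1NCC1=NCCN1` gives 108% in a functional assay with Alpha-1A adrenergic receptor (Homo sapiens) as the target, read by calcium flux (on this read-out lower numbers stand for smaller maximal responses and higher numbers for larger maximal responses), and stands highest of the three measured compounds. Compound 1 `CCCn1ncnc1-c1ccccc1NCC1=NCCN1` comes nearest with 96%, a gap beyond the scatter. Compound 3 `CC(C)n1nccc1-c1ccccc1NCC1=NCCN1` lies furthest away with 0%, which is a number 108 percentage points lower from compound 2 to compound 3 (beyond the scatter).

Compound 4 `c1ccc(-c2nc[nH]n2)c(NCC2=NCCN2)c1` differs from compound 2 in one place: 1H-1,2,4-triazol-3-yl in place of 1-methyl-1H-pyrazol-5-yl on an aromatic carbon. The change sits on an aromatic carbon of a six-membered aromatic ring of carbon only, ortho to a group of 7 heavy atoms.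

Within the data shown here, no measured step swaps one five-membered ring for another, so the only step that bears on the change is the one from compound 2 to compound 3, which shows that the group on the aromatic nitrogen of that ring decides the maximal response: the large drop of a number 108 percentage points lower from compound 2 to compound 3 (beyond the scatter) came from isopropyl in place of methyl alone. Compound 4 carries no alkyl on its ring nitrogen at all, so it lies outside the range of what was measured; compound 1, with propyl on a triazole, still gives 96%. A moderate loss is expected, with a wide range.

Compound 4 is therefore estimated at 70% in this assay, between 15% and 110%, meaning an expected step of a number 38 percentage points lower from compound 2 to compound 4 (beyond the scatter).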

Compound 4, largest response reached (reported as maximal response), in percent of the reference or control that the assay uses: 135%
For compound 4 the middle estimate is 65 percentage points below the measured one; measured number outside the range, above it.
By their numbers in this assay, from the lowest: compound 3; then compound 1; then compound 2; then compound 4.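

Position notes: on the aromatic carbon ortho to a group of 7 heavy atoms, the exchange of 1-methyl-1H-pyrazol-5-yl for 1H-1,2,4-triazol-3-yl in this assay gives a number 27 percentage points higher from compound 2 to compound 4 (beyond the scatter) and so raises the maximal response, where the only earlier step at a ring substituent, a number 108 percentage points lower from compound 2 to compound 3 (beyond the scatter), was a fall. A five-membered ring with no alkyl group on a ring nitrogen therefore keeps the response at this position, and the series is not confined to small alkyl groups there. The change alters several things at once, namely the ring hetero atoms, the point of attachment, the loss of methyl and the gain of a hydrogen-bond donor, and nothing available gives a reason for the rise.

Which of these differences carries the step stays open; a pyrazole with hydrogen on its ring nitrogen and a triazole with methyl on its ring nitrogen would separate them. Also open, from the compounds shown here alone, is where the response falls away between methyl and isopropyl, which an ethyl group on the pyrazole nitrogen would address.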